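Sulfonyl on the ring nitrogen: from compound 1 to compound 4

This account rests on a few compounds, and the source may have more. Where it says the series, first, only, none or still open, it means among the compounds named here.

Measured compounds:
compound 1, `COc1ccc(-c2cc(=O)c3c(OC)cc(OC)cc3[nH]2)cc1` — > 62000 nM
compound 2, `COC(=O)c1cc(=O)c2c(OC)cc(OC)cc2n1S(=O)(=O)c1ccc(C)cc1` — 139000 nM
compound 3, `COC(=O)c1cc(=O)c2cc(N)ccc2[nH]1` — > 67200 nM

Of the compounds shown here, three share a fused core and have been tested in an ADME assay on BJ cells (Homo sapiens) for antiproliferative activity, with a stated time of 72 h; a lower number here means that less compound is needed, a higher number that more compound is needed for the effect. For compound 1 the result is only a limit, > 62000 nM, at which the compound shows no measurable effect; it stands at the limit of > 62000 nM in this assay, at which 1 of the 3 values shown sits. Compound 3 likewise gives only a limit, > 67200 nM, and sits at the limit of > 67200 nM in this assay, at which 1 of the 3 values shown sits. Among the measured compounds shown here, compound 2, which carries an aryl sulfonyl on the same aromatic nitrogen of its core together with a methyl ester, is the one compound with a number, giving 139000 nM in this assay, a very weak effect.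

The unmeasured compound 4, `COc1ccc(-c2cc(=O)c3c(OC)cc(OC)cc3n2S(=O)(=O)c2ccc(F)cc2)cc1`, differs from compound 1 by (4-fluorophenyl)sulfonyl in place of hydrogen on an aromatic nitrogen. For the measured compounds named here, no pair of measured compounds differing in one place is available to size such a change. Compound 1 sits at a limit. Compound 2, which carries a related sulfonyl, gives only 139000 nM in this assay. A step in this assay is therefore expected to be at most small, and may be nothing beyond the scatter, a step that the limit leaves unreadable from compound 1 to compound 4. Compound 4 is therefore estimated at 100000 nM, with a range of 40000 nM to 300000 nM.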

Compound 4, half-maximal effective concentration: > 65500 nM
Compound 4: no number, only a limit; the forecaster's own chance of this, stated with the estimate: 50%; the middle value is on the limit's open side.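

In this assay compound 4 gives > 65500 nM, which is a limit and not a number. Among the compounds shown here, compound 1 is likewise a limit, at > 62000 nM, so no step between compound 1 and compound 4 can be read. The compounds shown leave open whether (4-fluorophenyl)sulfonyl in place of hydrogen on the aromatic nitrogen changes the effect at all.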